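Losing One Methyl from Compound 1

The source may report more compounds than this note shows. Statements on the series, on what has been measured and on what is new or still open speak of the compounds shown alone.

In an ADME assay on MT4 cells (Homo sapiens) for cytotoxicity, read by MTT assay (a higher number here means that more compound is tolerated, a lower number that less compound is tolerated), compound 1 (`Cc1cc(C)cc(S(=O)(=O)c2c(C(=O)NC(C)C(=O)NCCn3c(C)cnc3[N+](=O)[O-])[nH]c3ccc(Cl)cc23)c1`) gives 16000 nM, and compound 3 (`Cc1cc(C)cc(S(=O)(=O)c2c(C(=O)NC(C)C(=O)NC(C)c3ccccc3)[nH]c3ccc(Cl)cc23)c1`) gives 21700 nM. These two values lie within the scatter of each other. Compound 2 (`Cc1cc(C)cc(S(=O)(=O)c2c(C(=O)NCc3cccc(F)c3F)[nH]c3ccc(Cl)cc23)c1`) gives > 51100 nM, which is a limit of the assay and not a number.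

Compound 4 (`Cc1cc(C)cc(S(=O)(=O)c2c(C(=O)NCC(=O)NCCn3c(C)cnc3[N+](=O)[O-])[nH]c3ccc(Cl)cc23)c1`) is compound 1 with hydrogen in place of methyl on a saturated chain carbon bound to an amide-type nitrogen and a carbonyl carbon. Within the data shown here, no measured pair shows this change itself. Among the measured compounds shown here, the only guide is a much larger swap made elsewhere, on an amide-type nitrogen. With a 1.4-fold higher number from compound 1 to compound 3 (0.13 log units; within the scatter) as that guide, no step beyond the scatter is expected in this assay for the loss of this methyl. The expected step is a 1.1-fold higher number from compound 1 to compound 4 (0.05 log units; within the scatter). For compound 4 the estimated value is 18000 nM, with an expected range from 9000 nM to 40000 nM.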

Compound 4, half-maximal cytotoxic concentration: 24500 nM
Compound 4: the middle estimate sits 1.4-fold (0.13 log units) below what was measured; the measured number falls inside the stated range.
By their numbers in this assay, from the lowest: compounds 1, 3 and 4 (each within the scatter of the next). At a limit, above all of these: compound 2.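

Among these compounds, this is the first direct reading at this position. Hydrogen in place of methyl on a saturated chain carbon bound to an amide-type nitrogen and a carbonyl carbon gives a 1.5-fold higher number from compound 1 to compound 4 (0.19 log units; within the scatter) in this assay, whereas the earlier compounds offered only a much larger swap made elsewhere. In compound 1, then, this methyl can be lost with no step beyond the scatter in how much compound the cells tolerate, though nothing shown here offers an explanation for this result.

As far as these compounds go, whether the same change would read the same way in compound 3, with its different group on the amide-type nitrogen, remains open. Also open, from the compounds shown here alone, is what an ethyl group, a hydroxymethyl group or a carboxylic acid would do on this same carbon in place of the methyl.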